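The source may report more compounds than this note shows. Statements on the series, on what has been measured and on what is new or still open speak of the compounds shown alone.

Working notes on the series. Compound 2 `CC(C)n1cc(-c2ccnc3[nH]c(C4CCNCC4)cc23)ccc1=O` has an unsubstituted amine nitrogen in its six-membered non-aromatic ring. In an ADME assay on microsomes from liver (Homo sapiens) for metabolic stability (a lower number here means slower removal, a higher number faster removal of the compound), compound 2 gives only a limit, < 3 uL/min, not a number; this is the limit of < 3 uL/min in this assay, at which 1 of the 3 values shown sits. The two other measured members, compound 1 `CC(C)n1nc(-c2ccnc3[nH]c(C4CCN(CC(=O)N(C)C)CC4)cc23)ccc1=O` and compound 3 `CC(C)Cn1cc(-c2ccnc3[nH]c(C4CCN(CC(=O)N(C)C)CC4)cc23)ccc1=O`, each carry a group on that same amine nitrogen, and each also differs from compound 2 elsewhere in the core, so no single step can be read between either of them and compound 2. In this assay compound 1 gives 13 uL/min. In this assay compound 3 gives 21 uL/min. Those two values are within the usual scatter of each other.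

Compound 4 `CC(C)n1cc(-c2ccnc3[nH]c(C4CCN(CC(=O)N5CCCCC5)CC4)cc23)ccc1=O` has not yet been measured. It differs from compound 2 by ((piperidin-1-yl)carbonyl)methyl in place of hydrogen on an amine nitrogen in a ring. Taking the values of compound 1 and compound 3 as the only guide to what a group on this nitrogen brings in this assay, the step from compound 2 to compound 4 is expected to go upward, beyond the scatter, by about an at least 6.6-fold higher number from compound 2 to compound 4 (0.82 log units; beyond the scatter). Compound 4 is therefore estimated at 20 uL/min in this assay, with a plausible range from 8 uL/min to 50 uL/min.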

Compound 4, intrinsic clearance in a liver preparation (reported as CLH), per the amount of preparation that the assay uses: > 300 uL/min
Compound 4: no number, only a limit; the forecaster's own chance of this, stated with the estimate: 10%; at least 15-fold (1.17 log units) between middle value and limit.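

For the compounds shown here, with the rest of the structure held constant, ((piperidin-1-yl)carbonyl)methyl in place of hydrogen on the amine nitrogen in the ring gives an at least 100-fold higher number from compound 2 to compound 4 (2.00 log units; beyond the scatter), the first change at this position that can be read on its own and a large one. In this assay compound 2 gives < 3 uL/min, which is a limit and not a number: the limit of < 3 uL/min in this assay, at which 1 of the 4 values shown sits. In this assay compound 4 gives > 300 uL/min, which is also a limit and not a number: the limit of > 300 uL/min in this assay, at which 1 of the 4 values shown sits.

Open, going by these compounds, is how much of this step belongs to the piperidine ring and how much to the carbonylmethyl part, and what a methyl group, a carboxylic acid or a morpholine amide on this nitrogen would give on the core of compound 2. Compound 1 and compound 3 each differ from compound 2 and from compound 4 in more than one place, so steps to them cannot be read and their values cannot show how far the outcome depends on the amide group or on the core.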